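From 2,4-difluorobenzyl to 4-chlorobenzyl on a shared core

The compounds below may be only part of what the source reports. "The series", "measured", "known", "first", "only" and "open" are said of these compounds alone.

In a physicochemical assay for lipophilicity, read by HPLC (on this read-out lower numbers stand for lower lipophilicity and higher numbers for higher lipophilicity), compound 1 (`Cc1ccsc1C(=CCCN(C)C(CCO)C(=O)NCc1ccc(F)cc1F)c1sccc1C`) gives 6.37 and compound 2 (`Cc1ccsc1C(=CCCN(C)C(CCN)C(=O)NCc1ccc(F)cc1)c1sccc1C`) gives 6.45 on the same scale, so these two numbers stand within the usual scatter of each other. Compound 3 (`Cc1ccsc1C(=CCCN(C)C(CCO)C(=O)NCc1ccc(Cl)cc1)c1sccc1C`) has not been measured yet. It differs from compound 1 in one place, on a saturated chain carbon bound to an amide-type nitrogen, where 4-chlorophenyl stands in place of 2,4-difluorophenyl (4-chlorophenyl in place of 2,4-difluorophenyl on a saturated chain carbon bound to an amide-type nitrogen). Within the data shown here, no two measured compounds differ in only one place, so no measured step can guide this comparison, and the expectation rests on the structural change alone. A small rise is expected, with the estimated step of a number 0.38 log units higher from compound 1 to compound 3 (beyond the scatter) on the same scale. The estimate in this assay for compound 3 is 6.75 within an expected range of 6.4 to 7.1 and awaits measurement.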

Compound 3, partition coefficient: 6.38
For compound 3 the middle estimate is 0.37 log units above the measured one; measured number below the stated range.
By their numbers in this assay, from the lowest: compounds 1, 3 and 2 (each within the scatter of the next).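

In this assay, putting 4-chlorophenyl in place of 2,4-difluorophenyl on a saturated chain carbon bound to an amide-type nitrogen gives a number 0.01 log units higher from compound 1 to compound 3 (within the scatter). Among these compounds, this is the first comparison here in which only one place differs, and it shows that these two halogen-bearing rings cannot be told apart on this scale, even though one carries two fluorine atoms and the other one chlorine atom. Nothing available explains why the two rings read alike.

Only these two rings can be compared directly at this position, so one pair cannot show whether other rings would read alike. A phenyl ring carrying a carboxylic acid, an amine or a methoxy group could give a very different number here, and that remains an open question.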